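The source may report more compounds than this note shows. Statements on the series, on what has been measured and on what is new or still open speak of the compounds shown alone.

Measured so far in an ADME assay on HEK293 cells (Homo sapiens) for cytotoxicity, read by fluorescence and resazurin assay, with a stated time of 24 h; a lower number here means that less compound is tolerated, a higher number that more compound is tolerated:
compound 1 `O=S1(=O)C=C(Sc2nnc(-c3cccnc3)o2)c2ccccc21` gives 4000 nM;
compound 2 `COc1ccccc1-c1nnc(SC2=CS(=O)(=O)c3ccccc32)o1` gives 3000 nM.

Among the compounds with values here, of these two numbers, compound 1 has the larger one on paper, yet its only neighbour, compound 2, is separated from it by a 1.3-fold lower number from compound 1 to compound 2 (0.12 log units; within the scatter), a difference that falls within the scatter and therefore does not set the two compounds apart.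

Compound 3 `COc1cccc(-c2nnc(SC3=CS(=O)(=O)c4ccccc43)o2)c1` has not yet been tested in this assay. It differs from compound 1 by 3-methoxyphenyl in place of pyridin-3-yl on an aromatic carbon. Within the data shown here, the one measured step that bears on this change is the one in which a 2-methoxyphenyl took the place of the same pyridin-3-yl, a 1.3-fold lower number from compound 1 to compound 2 (0.12 log units; within the scatter), and that step stayed within the scatter. A 3-methoxyphenyl is a close structural relative of a 2-methoxyphenyl, and no step beyond the scatter is expected in this assay for compound 3 either.

For compound 3 the estimate is 3500 nM, with a range from 1500 nM to 8000 nM. This estimate means an expected step of a 1.1-fold lower number from compound 1 to compound 3 (0.06 log units; within the scatter).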

Compound 3, half-maximal cytotoxic concentration: 3000 nM
Beside the measured number, compound 3's estimate is 1.2-fold (0.07 log units) above it, and the stated range covers the measured number.
By their numbers in this assay, from the lowest: compounds 2, 3 and 1 (each within the scatter of the next).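

With 3-methoxyphenyl in place of pyridin-3-yl, this assay shows a 1.3-fold lower number from compound 1 to compound 3 (0.12 log units; within the scatter), so a second methoxyphenyl group at this position also stays level with the pyridin-3-yl compound. The new comparison between the two methoxyphenyl groups shows no change at the digits printed from compound 2 to compound 3 (within the scatter), which means that these two placements of the methoxy group on the phenyl ring are not told apart in this test. No independent measurement is available to explain why these three compounds stay so close.

As far as these compounds go, all three carry a six-membered aromatic ring at this position, so it remains open whether the same tolerance would hold with an amine, a carboxylic acid or a longer chain there. These compounds also leave open how changes elsewhere in the shared core would affect the reading.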